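The compounds below may be only part of what the source reports. "The series", "measured", "known", "first", "only" and "open" are said of these compounds alone.

Measured so far in an ADME assay on HaCaT cells (Homo sapiens) for inhibition, read by sulforhodamine B assay, with a stated time of 48 h; a lower number here means a stronger inhibitor of growth, a higher number a weaker inhibitor of growth:
compound 1 `COc1cc(/C=C/C2CC=CC(=O)O2)cc(OC)c1`: 8.8 uM
compound 2 `COc1cc(/C=C/C2CC=CC(=O)O2)cc(OC)c1OC`: 21.6 uM
compound 3 `COc1ccc(/C=C/C2CC=CC(=O)N2)cc1`: a limit only, > 1090 uM

From compound 1 to compound 2 the change is methoxy in place of hydrogen on an aromatic carbon and this assay shows a 2.5-fold higher number from compound 1 to compound 2 (0.39 log units; beyond the scatter). Compound 3 carries a different core; the difference between the two cores is not broken down here. For compound 3 this assay reports only a limit (the limit of > 1090 uM in this assay, at which 1 of the 3 values shown sits), not a number.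

Compound 4 `COc1ccc(/C=C/C2CC=CC(=O)N2)cc1OC` arises from compound 3 by methoxy in place of hydrogen on an aromatic carbon, the same kind of change as from compound 1 to compound 2, though the place differs: here the entering group sits ortho to a methoxy group and meta to a group of 9 heavy atoms, whereas in compound 2 it sits ortho to two methoxy groups and para to a group of 9 heavy atoms. The expected step is a step that the limit leaves unreadable from compound 3 to compound 4, resting on a 2.5-fold higher number from compound 1 to compound 2 (0.39 log units; beyond the scatter) and on compound 3 already standing at the limit. Compound 4 is therefore estimated at 1500 uM, with a range of 300 uM to 6000 uM, most likely reported again as a limit.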

Compound 4, concentration for growth inhibition (reported as GI): > 964 uM
Compound 4: only a limit was reported; the forecaster's own chance of this, stated with the estimate: 80%; the middle value lies beyond the limit too.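

Within the data shown here, compound 3 and compound 4 are both reported only as limits in this assay, so no step between them can be read. Going by these compounds, whether methoxy in place of hydrogen on an aromatic carbon changes growth inhibition on the core of compound 3 stays open.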